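Trading a ring oxygen for a hydroxyl and two methyls

The source may report more compounds than this note shows. Statements on the series, on what has been measured and on what is new or still open speak of the compounds shown alone.

This set concerns three measured compounds and one to come, all sharing a core that carries a nitrile, a trifluoromethyl group and two nitrogen linkers. Compound 1 `N#Cc1cnc(NCc2cnccc2C(F)(F)F)cc1N[C@H]1CC[C@@H](O)CC1` and compound 2 `N#Cc1cnc(NCc2cnccc2C(F)(F)F)cc1N[C@H]1CC[C@H](O)CC1` are mirror images, and in an assay on isolated protein for inhibition of protein kinase C delta type (Homo sapiens), read by TR-FRET, with a stated time of 2 h (on this read-out lower numbers stand for stronger inhibition and higher numbers for weaker inhibition), compound 1 gives 4500 nM while compound 2 gives 6500 nM; the difference of a 1.4-fold higher number from compound 1 to compound 2 (0.16 log units; within the scatter) is small, which fits (the fact that compounds 1 and 2 differ only in the configuration as drawn). Compound 3 `N#Cc1cnc(NCc2cnccc2C(F)(F)F)cc1NC1CCOCC1` carries an oxan-4-yl group instead and in this assay compound 3 gives 9800 nM, the highest of the three numbers: the step is a 2.2-fold higher number from compound 1 to compound 3 (0.34 log units; beyond the scatter) and a 1.5-fold higher number from compound 2 to compound 3 (0.18 log units; within the scatter).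

Compound 4 `CC1(C)C[C@@H](Nc2cc(NCc3cnccc3C(F)(F)F)ncc2C#N)CC[C@@H]1O` reverses that exchange and adds two methyls: 4-hydroxy-3,3-dimethylcyclohexyl in place of oxan-4-yl on a nitrogen on an aromatic ring. The two steps that bear on it both run from a 4-hydroxycyclohexyl group to an oxan-4-yl group and both went upward, one beyond the scatter and one within it, so going back the other way should lower the number by a modest amount. Among the measured compounds shown here, the two added methyl groups have no precedent among the measured compounds. For compound 4 the expected step is a 2.0-fold lower number from compound 3 to compound 4 (0.29 log units; within the scatter), giving an estimate of 5000 nM with a range from 2500 nM to 10000 nM in this assay.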

Compound 4, half-maximal inhibitory concentration: 2400 nM
Estimate against measurement, compound 4: 2.1-fold (0.32 log units) above; measured number below the stated range.
By their numbers in this assay, from the lowest: compounds 4, 1, 2 and 3 (each within the scatter of the next, the first and the last beyond it).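

At this nitrogen on the aromatic ring, the 4-hydroxy-3,3-dimethylcyclohexyl group does clearly better than oxan-4-yl in this assay, with a 4.1-fold lower number from compound 3 to compound 4 (0.61 log units; beyond the scatter), and it also does better than one of the two 4-hydroxycyclohexyl compounds, with a 2.7-fold lower number from compound 2 to compound 4 (0.43 log units; beyond the scatter). Against the other 4-hydroxycyclohexyl compound the result is less clear, with a 1.9-fold lower number from compound 1 to compound 4 (0.27 log units; within the scatter), so the two methyl groups show a measurable gain in only one of the two comparisons that could reveal one. The position therefore accepts the larger group with its two methyl groups without any loss in this assay, though the compounds shown give no measured reason for the step.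

As far as these compounds go, what remains open is how much of the result belongs to the two methyl groups and how much to the hydroxyl, a question that a single methyl group on the ring, or an amine in place of the hydroxyl, would help to separate. Also open, from the compounds shown here alone, is how the other arrangements of the two stereocentres in 4-hydroxy-3,3-dimethylcyclohexyl would compare with compound 4.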